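Prop-1-en-1-yl for Vinyl at a Cytotoxicity Limit

The compounds below may be only part of what the source reports. "The series", "measured", "known", "first", "only" and "open" are said of these compounds alone.

As far as these compounds go, in an ADME assay on L02 cells (Homo sapiens) for cytotoxicity, read by MTT assay, with a stated time of 72 h (a higher number here means a weaker inhibitor, a lower number a stronger inhibitor), compound 3 (`C=CC(=O)Nc1cccc(Oc2nc(Nc3ccc(OC)cc3)nc3c2CSCC3)c1`) gives > 50000 nM as a limit and not a number, so its exact place is unknown. Compound 1 (`C/C=C/C(=O)Nc1cccc(Oc2nc(Nc3cccc(OC)c3)nc3c2CSCC3)c1`) gives > 50000 nM as a limit too. Compound 2 (`C/C=C/C(=O)Nc1cccc(Oc2nc(Nc3cccc(C#N)c3)nc3c2CSCC3)c1`) gives > 50000 nM as a limit as well. The whole series therefore reads as a single entry (the limit of > 50000 nM in this assay, at which 3 of the 3 values shown sit) and offers no ranking.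

Compound 4 (`C/C=C/C(=O)Nc1cccc(Oc2nc(Nc3ccc(OC)cc3)nc3c2CSCC3)c1`) departs from compound 3 at one place, with prop-1-en-1-yl in place of vinyl on a carbonyl carbon as the whole difference. Among the measured compounds shown here, the only measured step (a step that the two limits leave unreadable from compound 1 to compound 2) is a different change and has no readable size to carry over. The closest guide is that compound 2 holds the prop-1-en-1-yl group that enters here and still stands at > 50000 nM as a limit in this assay without a number. No step beyond the scatter is expected in either direction. The expected change is a number no higher from compound 3 to compound 4 (the limit leaves the size open) and the assay will most likely again report only a limit. For compound 4 the estimated value is 50000 nM with an expected range from 25000 nM to 100000 nM and is likely to appear as a limit.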

Compound 4, half-maximal inhibitory concentration: > 50000 nM
Compound 4 was reported as a limit (the forecaster's own chance of this, stated with the estimate: 85%); the middle value lies on the limit itself.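

Compound 4 joins compounds 1, 2 and 3 at a limit in this assay, so none of its steps from compound 3, compound 2 or compound 1 can be read: the limit of > 50000 nM in this assay, at which 4 of the 4 values shown sit.

The compounds shown leave open what number any of them would give, and so whether prop-1-en-1-yl in place of vinyl on a carbonyl carbon changes the reading at all.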